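Allyloxy in place of allyl on the chain carbon

A few compounds are considered here, and "the series" means these few. Any claim that something is new, unique, unknown or untested is made for them only; others in the source may bear on it.

Compound 2, `C=CCCC1CC=CC(=O)O1`, stands at the edge of the measured range: in a functional assay on HT-29 cells (Homo sapiens) for cytotoxicity, read by MTT assay, with a stated time of 72 h (a higher number here means a weaker inhibitor, a lower number a stronger inhibitor), compound 2 gives > 100 ug/mL, which is a limit of the assay rather than a number. Within the data shown here, its one measured neighbour is compound 1, `CCC1CC=CC(=O)O1`. In this assay compound 1 gives > 100 ug/mL, again a limit. The step that the two limits leave unreadable from compound 1 to compound 2 is therefore not readable; both values sit at the limit of > 100 ug/mL in this assay, at which 2 of the 2 values shown sit. Compound 3, `C=CCOCC1CC=CC(=O)O1`, carries allyloxy in place of allyl on a saturated chain carbon bound to a saturated ring carbon. Among the measured compounds shown here, no measured step bears on this change with a readable size, so no direction can be taken from the set; the only information is that neither measured compound reached a number within the range of the assay. Compound 3 is accordingly expected to remain near that limit, with the step that the limit leaves unreadable from compound 2 to compound 3 estimated as none beyond the scatter. The estimate for compound 3 is 150 ug/mL, ranging from 60 ug/mL to 400 ug/mL.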

Compound 3, half-maximal inhibitory concentration: 18.4 ug/mL
Compound 3: middle estimate off by 8.2-fold (0.91 log units), on the high side; measured number outside the range, below it.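

In this assay, compound 3 is the only compound shown that gives a number rather than a limit, so the saturated chain carbon bound to a saturated ring carbon now has a change of readable size. Allyloxy in place of allyl gives an at least 5.4-fold lower number from compound 2 to compound 3 (0.73 log units; beyond the scatter), and allyloxy in place of methyl gives an at least 5.4-fold lower number from compound 1 to compound 3 (0.73 log units; beyond the scatter). Both sizes are bounds and not exact differences, because compound 1 and compound 2 each stay at a limit: the limit of > 100 ug/mL in this assay, at which 2 of the 3 values shown sit.

From the compounds shown here alone, the step from compound 1 to compound 2 cannot be read, and the true size of both new steps stays open. Going by these compounds, whether the step follows the oxygen of the allyloxy group or the group as a whole also stays open; a propoxy group, a benzyloxy group or an amine at this place would bear on that.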